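Piperazin-1-yl exchange on compound 3: half-life expected

The source may report more compounds than this note shows. Statements on the series, on what has been measured and on what is new or still open speak of the compounds shown alone.

In an ADME assay on microsomes from liver (Mus musculus) for metabolic stability (on this read-out higher numbers stand for a longer-lived compound and lower numbers for a shorter-lived compound), compound 1 `NC(=O)CNC(=O)C[C@H]1CC[C@]2(CC1)OO[C@]1(O2)C2CC3CC(C2)CC1C3` gives 2.07 h and compound 2 `O=C(C[C@H]1CC[C@]2(CC1)OO[C@]1(O2)C2CC3CC(C2)CC1C3)N1CCNCC1` gives 0.802 h. Compound 3 `NC(=O)CNC(=O)C[C@@H]1CCC[C@]2(C1)OOC1(O2)C2CC3CC(C2)CC1C3` gives 0.622 h. This value lies within the scatter of compound 2 and beyond the scatter under compound 1.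

The change to follow leads from compound 3 to compound 4 `O=C(C[C@@H]1CCC[C@]2(C1)OOC1(O2)C2CC3CC(C2)CC1C3)N1CCNCC1`: piperazin-1-yl in place of (carbamoylmethyl)amino on a carbonyl carbon. In words, piperazin-1-yl takes the place of (carbamoylmethyl)amino on a carbonyl carbon.

Within the data shown here, one measured step bears on this, the same exchange on the core of compound 1: a 2.6-fold lower number from compound 1 to compound 2 (0.41 log units; beyond the scatter). It is modest and beyond the scatter, but it is a single pair on a different core, so it sets the direction and only roughly the size. In this assay the expected step is a 2.2-fold lower number from compound 3 to compound 4 (0.35 log units; beyond the scatter), a lower number of similar size. Compound 4 is estimated at 0.28 h, with an expected range from 0.13 h to 0.62 h.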

Compound 4, half-life: 0.425 h
Beside the measured number, compound 4's estimate is 1.5-fold (0.18 log units) below it; measured number inside the range.
By their numbers in this assay, from the lowest: compounds 4, 3 and 2 (each within the scatter of the next); then compound 1.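

Read in this assay, the same exchange on the core of compound 3 comes out as a 1.5-fold lower number from compound 3 to compound 4 (0.17 log units; within the scatter). Among these compounds, on this core, then, replacing (carbamoylmethyl)amino with piperazin-1-yl on the carbonyl carbon gives no step that stands clear of the scatter, unlike the step on the core of compound 1. The two steps nevertheless remain compatible, so a single size of step on both cores fits the data, and no dependence on the core is established: the same change on two cores in this assay, a 2.6-fold lower number (0.41 log units; beyond the scatter) from compound 1 to compound 2 and a 1.5-fold lower number (0.17 log units; within the scatter) from compound 3 to compound 4, 1.8-fold (0.25 log units) apart, within the scatter of two such steps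

Among the compounds shown here, with only one pair per core, it remains open whether the size of this step differs between the cores at all. Also open, as far as these compounds go, is how other groups on the same carbonyl carbon would behave in this assay, such as morpholin-4-yl, dimethylamino or a piperazin-1-yl carrying a methyl group on its free nitrogen.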